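Swapping 3-fluorophenyl for pyridin-4-yl on the shared core

A few compounds are considered here, and "the series" means these few. Any claim that something is new, unique, unknown or untested is made for them only; others in the source may bear on it.

Values in an ADME assay (liver) for metabolic stability, with Liver microsome (Homo sapiens) as the target, using microsomes and NADPH, with a stated time of 30 min, tested at 1 uM; a lower number here means slower removal, a higher number faster removal of the compound:
- compound 1 `COc1cc(C(O)(C(F)(F)F)C(F)(F)F)cnc1N1CCN(S(=O)(=O)c2ccc(N)nc2)CC1`: < 14 mL.min-1.g-1 (a limit of the assay, not a number)
- compound 2 `CC(C)(C)n1cc(-c2cc(C(O)(C(F)(F)F)C(F)(F)F)cnc2N2CCN(S(=O)(=O)c3ccc(N)nc3)CC2)cn1`: 86 mL.min-1.g-1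
- compound 3 `Nc1ccc(S(=O)(=O)N2CCN(c3ncc(C(O)(C(F)(F)F)C(F)(F)F)cc3-c3cccc(F)c3)CC2)cn1`: 25 mL.min-1.g-1

Compound 3 has the lower of the two actual numbers, and compound 1 has only a limit. Compound 4 `Nc1ccc(S(=O)(=O)N2CCN(c3ncc(C(O)(C(F)(F)F)C(F)(F)F)cc3-c3ccncc3)CC2)cn1` carries pyridin-4-yl in place of 3-fluorophenyl on an aromatic carbon. Two measured steps changed this same place: a 3.4-fold lower number from compound 2 to compound 3 (0.54 log units; beyond the scatter) and an at least 1.7-fold higher number from compound 1 to compound 3 (0.25 log units; that floor lies within the scatter). The group here can clearly move the number, as an at least 6.1-fold higher number from compound 1 to compound 2 (0.78 log units; beyond the scatter) also shows. This time one six-membered aromatic ring replaces another, so only a small downward change is expected. The expected step is a 1.4-fold lower number from compound 3 to compound 4 (0.14 log units; within the scatter). For compound 4 the estimated value is 18 mL.min-1.g-1, with an expected range from 10 mL.min-1.g-1 to 35 mL.min-1.g-1.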

Compound 4, intrinsic clearance in microsomes: 15 mL.min-1.g-1
Compound 4: the middle estimate sits 1.2-fold (0.08 log units) above what was measured; low and high end bracket the measured number.
By their numbers in this assay, from the lowest: compounds 4 and 3 (each within the scatter of the next); then compound 2. At a limit, below all of these: compound 1.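

The step for pyridin-4-yl in place of 3-fluorophenyl is a 1.7-fold lower number from compound 3 to compound 4 (0.22 log units; within the scatter), so at this position these two six-membered aromatic rings cannot be told apart in clearance. The high number stays with the pyrazole group alone, as pyridin-4-yl in its place gives a 5.7-fold lower number from compound 2 to compound 4 (0.76 log units; beyond the scatter). The remaining step, an at least 1.0-fold higher number from compound 1 to compound 4 (0.02 log units; that floor lies within the scatter), cannot be read, since it rests on a limit and not on a number: the limit of < 14 mL.min-1.g-1 in this assay, at which 1 of the 4 values shown sits.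

From the compounds shown here alone, what an amine or a carboxylic acid on this aromatic carbon would do to clearance stays open. So does the effect of pyridin-3-yl.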